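Chain oxygen at the nitrogen substituent of compound 3

A few compounds are considered here, and "the series" means these few. Any claim that something is new, unique, unknown or untested is made for them only; others in the source may bear on it.

The three measured compounds share one core and differ only in the chain pair on the ring-bound nitrogen. In an assay on HEK293 cells for displacement of a labelled ligand from corticotropin-releasing factor receptor 1 (Homo sapiens) (on this read-out higher numbers stand for weaker inhibition and lower numbers for stronger inhibition), compound 1 `CCCCCN(CC1CC1)c1cc(C)nc2c(-c3ccc(Cl)cc3Cl)nn(C)c12` gives 1.5 nM, compound 2 `CCCCCN(CCC)c1cc(C)nc2c(-c3ccc(Cl)cc3Cl)nn(C)c12` gives 1.2 nM, and compound 3 `CCCCCN(CCCC)c1cc(C)nc2c(-c3ccc(Cl)cc3Cl)nn(C)c12` gives 0.9 nM. Compound 3 carries the lowest of the three numbers, yet the gaps to the others are small: a 1.7-fold lower number from compound 1 to compound 3 (0.22 log units; within the scatter) and a 1.3-fold lower number from compound 2 to compound 3 (0.12 log units; within the scatter), so no order among the three can be claimed on this assay.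

Compound 4 `CCCCN(CCCOC)c1cc(C)nc2c(-c3ccc(Cl)cc3Cl)nn(C)c12` differs from compound 3 by methoxy in place of ethyl on a saturated chain carbon, three bonds along the chain from a nitrogen on an aromatic ring. Going by the values given here, the steps that bear on it are those at the same nitrogen substituent: a 1.3-fold lower number from compound 1 to compound 2 (0.10 log units; within the scatter), a 1.7-fold lower number from compound 1 to compound 3 (0.22 log units; within the scatter) and a 1.3-fold lower number from compound 2 to compound 3 (0.12 log units; within the scatter), every one of them within the scatter. Among the compounds with values here, none of them brings an oxygen into the chain, so the hydrogen-bond acceptor that enters with the methoxy has no measured counterpart. Given that all changes at this position so far have left this assay essentially flat, compound 4 is expected to stay close to compound 3, with at most a small rise in the number; the expected step is a 1.7-fold higher number from compound 3 to compound 4 (0.22 log units; within the scatter). The estimate for compound 4 in this assay is 1.5 nM, with a range from 0.5 nM to 5 nM.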

Compound 4, inhibition constant: 18 nM
For compound 4 the middle estimate is 12-fold (1.08 log units) below the measured one; the measured number lies above the stated range.
By their numbers in this assay, from the lowest: compounds 3, 2 and 1 (each within the scatter of the next); then compound 4.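

In this assay, going by these compounds alone, methoxy in place of ethyl on a saturated chain carbon, three bonds along the chain from a nitrogen on an aromatic ring, gives a 20-fold higher number from compound 3 to compound 4 (1.30 log units; beyond the scatter), and this is the only step at this nitrogen substituent that lies beyond the scatter. The position is therefore not indifferent to every change: the exchanges among cyclopropyl, ethyl and propyl all stayed within the scatter, whereas this one, with 2 heavy atoms leaving and 2 entering, replaces a carbon with an oxygen and adds 1 hydrogen-bond acceptor. Nothing in the available data accounts for the size of this step.

With a single oxygen-bearing chain in the compounds shown, it remains open whether the rise in the number is tied to this place along the chain or would follow an oxygen anywhere in it. A 2-methoxyethyl chain, a longer ether chain, a hydroxyl or an amine at this nitrogen substituent would separate these readings and show how far the rise extends.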